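The source may hold more compounds than are shown below. What is called first, only, known or untested is meant among the compounds shown, and "the series" means these compounds.

Compound 1 `O=C(CN(c1nc(Cl)nc2[nH]cnc12)C1CC1)NCC(=O)OCc1ccccc1` gives 41.9% in a functional assay on the whole organism (Tail, strain ICR) with Mus musculus as the target, in the tail flick test, with a stated time of 60 min, at a dose of 25 umol/kg by the oral route; a lower number here means a weaker effect, a higher number a stronger effect of the compound at the dose given. Compound 2 `C[C@@H](O)[C@H](NC(=O)CN(c1nc(Cl)nc2[nH]cnc12)C1CC1)C(=O)OCc1ccccc1` gives 29.7%, and compound 3 `NCCCC[C@H](NC(=O)CN(c1nc(Cl)nc2[nH]cnc12)C1CC1)C(=O)OCc1ccccc1` gives 41.2%. Compound 3 stands second of the three numbers: its value and that of compound 1 lie within the scatter of each other, whereas a number 11.5 percentage points higher from compound 2 to compound 3 (beyond the scatter). Compound 4 `NC(=O)CC[C@H](NC(=O)CN(c1nc(Cl)nc2[nH]cnc12)C1CC1)C(=O)OCc1ccccc1` carries carbamoyl in place of 2-aminoethyl on a saturated chain carbon, three bonds along the chain from an amide-type nitrogen and a carbonyl carbon. Among the measured compounds shown here, the steps that bear on this change are a number 0.7 percentage points lower from compound 1 to compound 3 (within the scatter) and a number 11.5 percentage points higher from compound 2 to compound 3 (beyond the scatter); compound 2, the other compound without a 4-aminobutyl chain, sits lowest, and the carbamoyl of compound 4 likewise lacks the amine of compound 3. A modest downward step is therefore expected for compound 4, a number 8.2 percentage points lower from compound 3 to compound 4 (within the scatter), and its activity is estimated at 33%, with a range of 21% to 45%.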

Compound 4, a percentage reported as activity, at one dose (the size of the read-out at that dose, not a potency): 33.1%
Beside the measured number, compound 4's estimate is 0.1 percentage points below it, within the range that was stated.
By their numbers in this assay, from the lowest: compounds 2, 4, 3 and 1 (each within the scatter of the next, the first and the last beyond it).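

At this position, carbamoyl in place of 2-aminoethyl gives (a number 8.1 percentage points lower from compound 3 to compound 4 (within the scatter)), so this change to the amine-bearing chain does not separate compound 4 from compound 3. The 2-carbamoylethyl chain also stays within the scatter of the other side chains (a number 3.4 percentage points higher from compound 2 to compound 4 (within the scatter); a number 8.8 percentage points lower from compound 1 to compound 4 (within the scatter)), although compound 1 and compound 2 lie beyond the scatter of each other, so compound 4 groups with neither one alone. Nothing available gives a reason for these steps.

On these data alone, a carboxylic acid in place of the carbamoyl remains open, as does a longer chain ending in an amine.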